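This account rests on a few compounds, and the source may have more. Where it says the series, first, only, none or still open, it means among the compounds named here.

Measured so far in an ADME assay on L02 cells (Homo sapiens) for cytotoxicity, read by MTT assay, with a stated time of 72 h; a lower number here means a stronger inhibitor, a higher number a weaker inhibitor:
compound 1, `Cc1ccccc1NC(=O)CCC(=O)OCCCCCCSc1ccc([N+](=O)[O-])c2nonc12`, 9490 nM;
compound 2, `O=C(CCC(=O)OCCCCCCSc1ccc([N+](=O)[O-])c2nonc12)Nc1ccc(F)cc1`, 6460 nM;
compound 3, `COc1ccc(NC(=O)CCC(=O)OCCCCCCSc2ccc([N+](=O)[O-])c3nonc23)cc1OC`, 4100 nM.

Compound 2 sits between the other two numbers; its gap to compound 1 and its gap to compound 3 are both within the scatter, so no order among the three is claimed. Compound 4, `O=C(CCC(=O)OCCCCCCSc1ccc([N+](=O)[O-])c2nonc12)NCCN1CCCC1`, differs from compound 2 in one place: 2-(pyrrolidin-1-yl)ethyl in place of 4-fluorophenyl on an amide-type nitrogen. The three steps seen so far, a 1.5-fold lower number from compound 1 to compound 2 (0.17 log units; within the scatter), a 2.3-fold lower number from compound 1 to compound 3 (0.36 log units; beyond the scatter) and a 1.6-fold lower number from compound 2 to compound 3 (0.20 log units; within the scatter), each swap one six-membered aromatic ring of carbon only for another on the same nitrogen; none puts a 2-(pyrrolidin-1-yl)ethyl or any five-membered non-aromatic ring there, so they bear only loosely on this change. Those swaps moved the numbers little, and no step beyond the scatter is expected in this assay. Compound 4 is therefore estimated at 7000 nM, range 2500 nM to 20000 nM, an expected step of a 1.1-fold higher number from compound 2 to compound 4 (0.03 log units; within the scatter).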

Compound 4, half-maximal inhibitory concentration: 6580 nM
For compound 4 the middle estimate is 1.1-fold (0.03 log units) above the measured one, within the range that was stated.
By their numbers in this assay, from the lowest: compounds 3, 2, 4 and 1 (each within the scatter of the next, the first and the last beyond it).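

In this assay the change from an aryl group to a non-aromatic one on the amide-type nitrogen gives a 1.0-fold higher number from compound 2 to compound 4 (0.01 log units; within the scatter) and a 1.6-fold higher number from compound 3 to compound 4 (0.21 log units; within the scatter) and also a 1.4-fold lower number from compound 1 to compound 4 (0.16 log units; within the scatter) with all three within the scatter. The 2-(pyrrolidin-1-yl)ethyl group thus shows that, among these compounds, this position can carry a five-membered non-aromatic ring with 1 hetero atom instead of a six-membered aromatic ring of carbon only without a step beyond the scatter.

From the compounds shown here alone, whether a carboxylic acid, a morpholine ring or a longer chain in place of the ethyl on the same nitrogen would give such a step remains open. No measurement at hand accounts for these small steps.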